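Swapping an alkenyl chain for a chlorophenyl group

The source may report more compounds than this note shows. Statements on the series, on what has been measured and on what is new or still open speak of the compounds shown alone.

Compound 1 `CC(C)=CC(O)C1=CC(=O)c2ccccc2C1=O`: 5200 nM
Compound 2 `O=C1C=C([C@H](O)c2ccccc2)C(=O)c2ccccc21`: 4300 nM
Compound 3 `O=C(C1=CC(=O)c2ccccc2C1=O)c1ccccc1`: 63400 nM

These three compounds share one core and were measured in a functional assay on WHCO1 cells (Homo sapiens) for cytotoxicity, read by MTT assay, with a stated time of 24 h; on this read-out lower numbers stand for stronger inhibition and higher numbers for weaker inhibition. Compound 1 gives 5200 nM, the second highest of the three numbers. Compound 2 gives 4300 nM, which lies within the usual scatter of compound 1, so no order between these two can be claimed. Compound 3 gives 63400 nM, a number far beyond the scatter from compound 1; compound 3 also lacks the hydroxyl on the saturated carbon that compound 1 and compound 2 carry.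

Compound 4 `O=C1C=C(C(O)c2ccc(Cl)cc2)C(=O)c2ccccc21` has not yet been measured. It differs from compound 1 by 4-chlorophenyl in place of 2-methylprop-1-en-1-yl on a saturated chain carbon bound to a double-bonded ring carbon and an oxygen on a saturated carbon. Compound 2 carries a plain phenyl group in place of the alkenyl chain of compound 1 and its number sits within the scatter of compound 1, so an aromatic ring there has not moved the number much. The step from compound 1 to compound 4 is expected to be small, a 1.4-fold lower number from compound 1 to compound 4 (0.14 log units; within the scatter), staying within the scatter. Compound 4 is estimated at 3800 nM, with a range from 1300 nM to 11000 nM.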

Compound 4, half-maximal inhibitory concentration: 3000 nM
For compound 4 the middle estimate is 1.3-fold (0.10 log units) above the measured one; the measured number falls inside the stated range.
By their numbers in this assay, from the lowest: compounds 4, 2 and 1 (each within the scatter of the next); then compound 3.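

In this assay the swap of 2-methylprop-1-en-1-yl for 4-chlorophenyl gives a 1.7-fold lower number from compound 1 to compound 4 (0.24 log units; within the scatter) and so no change can be claimed at this saturated chain carbon. The earlier compounds shown here showed this only for a plain phenyl ring, whereas this result shows that a ring carrying a chlorine also leaves the number within the scatter of the alkenyl chain. No measurement shown here explains why the number holds at this place.

The compounds shown leave open whether a quite different group on this carbon, such as a longer alkyl chain or a phenyl ring carrying a carboxylic acid, would keep the number in this range. They also leave open what an amine or a methoxy group on the phenyl ring would do in place of the chlorine.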